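Silyl and nitro ethers on a shared oximate core

The source may hold more compounds than are shown below. What is called first, only, known or untested is meant among the compounds shown, and "the series" means these compounds.

Measured so far:
compound 1 `C[n+]1ccn(COCC[Si](C)(C)C)c1/C=N/O` — -0.34
compound 2 `C[n+]1ccn(COCCC[Si](C)(C)C)c1/C=N/O` — 0.43
compound 3 `C[n+]1ccn(COCC(C)(C)[N+](=O)[O-])c1/C=N/O` — -1.96

In a physicochemical assay for lipophilicity (on this read-out higher numbers stand for higher lipophilicity and lower numbers for lower lipophilicity), compound 3 stands lowest of the three; the nearest number is that of compound 1, a number 1.62 log units lower from compound 1 to compound 3 (beyond the scatter), and the furthest that of compound 2, a number 2.39 log units lower from compound 2 to compound 3 (beyond the scatter). Compound 4 `C[n+]1ccn(COCCS(C)(=O)=O)c1/C=N/O` differs from compound 3 by (methylsulfonyl)methyl in place of 1-methyl-1-nitroethyl on a saturated chain carbon bound to an oxygen on a saturated carbon. Going by the values given here, both large steps into compound 3 run from a silyl-bearing group to the nitro group; none of the measured steps involves a sulfone, so they bear only loosely on this change. A modest further drop is expected, a number 0.54 log units lower from compound 3 to compound 4 (beyond the scatter), and for compound 4 in this assay the estimate is -2.5, with a range from -3.2 to -1.8.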

Compound 4, distribution coefficient: < -3.3
Compound 4 was reported as a limit; the forecaster's own chance of this, stated with the estimate: 5%; middle value at least 0.80 log units away from the limit.
By their numbers in this assay, from the lowest: compound 3; then compound 1; then compound 2. At a limit, below all of these: compound 4.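

In this assay compound 4 is reported only as a limit, not a number: the limit of < -3.3 in this assay, at which 1 of the 4 values shown sits.

Even so, (methylsulfonyl)methyl at this place on the saturated chain carbon puts compound 4 past all three earlier compounds, with a number at least 1.34 log units lower from compound 3 to compound 4 (beyond the scatter), a number at least 2.96 log units lower from compound 1 to compound 4 (beyond the scatter) and a number at least 3.73 log units lower from compound 2 to compound 4 (beyond the scatter). Going by these compounds alone, this place therefore spans more than the earlier compounds showed, their widest step being a number 2.39 log units lower from compound 2 to compound 3 (beyond the scatter).

Open, going by these compounds, is whether a sulfonamide or a carboxylic acid at this place would reach the same limit. Also open, on these data alone, is whether a longer chain carrying the methylsulfonyl group would return a number.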